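The source may hold more compounds than are shown below. What is called first, only, known or untested is meant among the compounds shown, and "the series" means these compounds.

Working notes on the series. Compound 1 `CC(=O)Nc1ccc2[nH]c(=O)n(O)c(=O)c2c1` in an assay on isolated protein for inhibition of Flap endonuclease 1 (Homo sapiens) (on this read-out lower numbers stand for stronger inhibition and higher numbers for weaker inhibition), gives 2000 nM. Compound 2 `COc1nc(-c2cccs2)nc(C(=O)O)c1O` in this assay gives "not determined" (no result reported), so no number is in hand for it. Compound 3 `O=C(NCCO)c1nc(-c2cccs2)[nH]c(=O)c1O` in this assay gives 4000 nM. Among the two numbers in hand, compound 3 stands at the higher end, with compound 1 as its only neighbour; the two values lie within the usual scatter of each other, so no order between them can be drawn, and compound 2 adds nothing to the comparison.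

The next entry, compound 4 `O=C(Nc1ccc(F)cc1)c1nc(-c2cccs2)[nH]c(=O)c1O`, is not yet measured in this assay. It differs from compound 3 in one place: 4-fluorophenyl in place of 2-hydroxyethyl on an amide-type nitrogen. Going by the values given here, no step between two measured compounds describes such an exchange, so there is no measured precedent to lean on; the change replaces an open-chain group by an aromatic ring on the same amide nitrogen, and the rest of the shared core is kept.

Expectation: a moderate move toward a lower number is the working estimate for the step from compound 3 to compound 4, a 2.7-fold lower number from compound 3 to compound 4 (0.43 log units; beyond the scatter), but a result that stays within the scatter of compound 3 would not be surprising. For compound 4 the estimated value in this assay is 1500 nM, with a range from 300 nM to 8000 nM.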

Compound 4, half-maximal inhibitory concentration: 10500 nM
Compound 4: the middle estimate sits 7.0-fold (0.85 log units) below what was measured; the measured number lies above the stated range.
By their numbers in this assay, from the lowest: compounds 1 and 3 (each within the scatter of the next); then compound 4.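

Going by these compounds alone, the only measured exchange at this position is 4-fluorophenyl in place of 2-hydroxyethyl on the amide-type nitrogen, and in this assay it gives a 2.6-fold higher number from compound 3 to compound 4 (0.42 log units; beyond the scatter). The position is therefore not indifferent to what it carries, and here a six-membered aromatic ring of carbon only, in place of an open chain with a hydrogen-bond donor and acceptor, does not bring a lower number. Nothing in hand links this modest step to a measured property of either group, so what accounts for it remains unsettled.

Within the data shown here, the single exchange changes the ring, the chain and the terminal hydroxyl together, so the contribution of each stays open; an unsubstituted phenyl, a 2-methoxyethyl group or a longer chain ending in hydroxyl on the same nitrogen would begin to separate them. Also open, going by these compounds, is how a terminal amine or a carboxylic acid on that chain would compare with the 2-hydroxyethyl group of compound 3, and in which direction the number would move.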